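Aryl thioether variation on the side chain: compound 4

The source may hold more compounds than are shown below. What is called first, only, known or untested is meant among the compounds shown, and "the series" means these compounds.

Measured so far in an assay on RBL-2H3 cells for inhibition of Polyunsaturated fatty acid 5-lipoxygenase (Rattus norvegicus); a higher number here means a weaker inhibitor, a lower number a stronger inhibitor:
- compound 1 `CCCCN(O)C(=O)Nc1cc([C@@H]2CC[C@@H](c3cc(OC)c(OC)c(OC)c3)O2)cc(OC)c1OCCSc1ccc(Br)cc1` gives 19 nM
- compound 2 `CCCCN(O)C(=O)Nc1cc([C@@H]2CC[C@@H](c3cc(OC)c(OC)c(OC)c3)O2)cc(OC)c1OCCS(=O)(=O)c1c(F)c(F)cc(F)c1F` gives 520 nM
- compound 3 `CCCCN(O)C(=O)Nc1cc([C@@H]2CC[C@@H](c3cc(OC)c(OC)c(OC)c3)O2)cc(OC)c1OCCSc1cccc(Br)c1` gives 43 nM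

Compound 3 stands second highest of the three numbers in this assay. Its nearest neighbour is compound 1, which gives 19 nM; the furthest is compound 2, which gives 520 nM.

Compound 4 `CCCCN(O)C(=O)Nc1cc([C@@H]2CC[C@@H](c3cc(OC)c(OC)c(OC)c3)O2)cc(OC)c1OCCSc1ccc(OC)cc1` differs from compound 3 in one place: 4-methoxyphenyl in place of 3-bromophenyl on a sulfur.

Among the compounds with values here, only one measured step touches the aryl ring on the sulfur, a 2.3-fold higher number from compound 1 to compound 3 (0.35 log units; beyond the scatter), which changed 4-bromophenyl to 3-bromophenyl. Compound 2 differs from compound 3 in two places at once, so its value bears only loosely on this change; it shows that a sulfone with a tetrafluorophenyl ring gives a much higher number than either thioether. Within the data shown here, compound 4 carries its substituent in the 4-position, as compound 1 does, but the substituent is methoxy rather than bromine, for which no step exists. Because of a 2.3-fold higher number from compound 1 to compound 3 (0.35 log units; beyond the scatter), a modest step back down is expected, estimated as a 1.7-fold lower number from compound 3 to compound 4 (0.24 log units; within the scatter), with wide uncertainty from the unmeasured bromine-to-methoxy exchange.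

Compound 4 is therefore estimated at 25 nM in this assay, within a range of 8 nM to 80 nM.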

Compound 4, half-maximal inhibitory concentration: 71 nM
Compound 4: the middle estimate sits 2.8-fold (0.45 log units) below what was measured; low and high end bracket the measured number.
By their numbers in this assay, from the lowest: compound 1; then compounds 3 and 4 (each within the scatter of the next); then compound 2.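

In this assay, methoxy in place of bromo on the aromatic ring gives a 3.7-fold higher number from compound 1 to compound 4 (0.57 log units; beyond the scatter), so the substituent on this aryl thioether affects the number even when the ring stays on the same sulfur; with a 2.3-fold higher number from compound 1 to compound 3 (0.35 log units; beyond the scatter) alongside it, both changes away from the 4-bromophenyl group lie beyond the scatter, though both are modest. The direct exchange of 3-bromophenyl for 4-methoxyphenyl gives a 1.7-fold higher number from compound 3 to compound 4 (0.22 log units; within the scatter) and stays within the scatter, so compound 3 and compound 4 cannot be separated in this assay although the two rings differ in both substituent and substitution pattern. Nothing measured here accounts for the difference between the bromo and methoxy rings.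

Still open, from the compounds shown here alone, is whether chlorine, a methyl group or a trifluoromethyl group in place of the bromine would hold a number near that of compound 1 at 19 nM in this assay, and how an unsubstituted phenyl ring on the sulfur would compare. Compound 2 at 520 nM also leaves the sulfone and the tetrafluorophenyl ring unseparated, which a 4-bromophenyl sulfone would resolve.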